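A Trifluoromethoxy Variant of Compound 1

A few compounds are considered here, and "the series" means these few. Any claim that something is new, unique, unknown or untested is made for them only; others in the source may bear on it.

Compound 1 `Cc1cc(C)nc(Oc2ccc(NC(=O)Nc3ccccc3)cc2)n1` was tested in a functional assay on KB cells (Homo sapiens) for cytotoxicity, read by MTT assay, with a stated time of 3 days; a lower number here means a stronger inhibitor, a higher number a weaker inhibitor. In this assay compound 1 gives > 50000 nM, which is a limit of the assay and not a number. Compound 2 `Cc1cccc(NC(=O)Nc2ccc(Oc3nc(C)cc(C)n3)cc2)c1` carries a methyl in place of hydrogen on an aromatic carbon. In this assay compound 2 gives > 50000 nM, again a limit rather than a number. The step that the two limits leave unreadable from compound 1 to compound 2 is therefore unreadable, since both values sit at the limit of > 50000 nM in this assay, at which 2 of the 2 values shown sit. Compound 1 thus stands only at this limit, with no measured value on either side of it.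

Compound 3 `Cc1cc(C)nc(Oc2ccc(NC(=O)Nc3ccc(OC(F)(F)F)cc3)cc2)n1` differs from compound 1 by trifluoromethoxy in place of hydrogen on an aromatic carbon. For the measured compounds named here, only the step from compound 1 to compound 2 bears on this change, and its size cannot be read, so no direction beyond the scatter can be drawn from it. Compound 3 is expected to give 50000 nM, within 20000 nM to 200000 nM, in this assay. The step of a number no higher from compound 1 to compound 3 (the limit leaves the size open) is accordingly estimated as none readable, with a high chance that this assay again reports only a limit.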

Compound 3, half-maximal inhibitory concentration: 28900 nM
Estimate against measurement, compound 3: 1.7-fold (0.24 log units) above; measured number inside the range.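

In this assay compound 3 gives 28900 nM, which is a measured number and not a limit, something neither earlier compound provided. With trifluoromethoxy on an aromatic carbon para to a large group, the result is an at least 1.7-fold lower number from compound 1 to compound 3 (0.23 log units; that floor lies within the scatter); the change therefore shows that a substituent on this ring can bring a number into the readable range of the assay, although the guaranteed size of the step does not pass beyond the scatter. The true size of the step may be larger, but it stays open because compound 1 gives only a limit, and the methyl step, which involves two limits, cannot be read at all: the limit of > 50000 nM in this assay, at which 2 of the 3 values shown sit.

The compounds shown leave open whether this readable number is particular to trifluoromethoxy or would also appear with a chlorine atom, an amine or a carboxylic acid at the same place. They also leave open whether a longer chain there, or trifluoromethoxy on another carbon of the ring, would give a number of similar size.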